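Acetylated triazole glycosides bearing an aryl-methylidene oxindole: thiophene analog

A few compounds are considered here, and "the series" means these few. Any claim that something is new, unique, unknown or untested is made for them only; others in the source may bear on it.

Measured so far:
- compound 1 `CC(=O)OC[C@H]1O[C@@H](n2cc(CN3C(=O)/C(=C\c4ccccc4)c4ccccc43)nn2)[C@H](OC(C)=O)[C@@H](OC(C)=O)[C@@H]1OC(C)=O`: 24300 nM
- compound 2 `CC(=O)OC[C@H]1O[C@@H](n2cc(CN3C(=O)/C(=C\C=C\c4ccccc4)c4ccccc43)nn2)[C@H](OC(C)=O)[C@@H](OC(C)=O)[C@@H]1OC(C)=O`: 34100 nM
- compound 3 `CC(=O)OC[C@H]1O[C@@H](n2cc(CN3C(=O)/C(=C/C=C/c4ccccc4)c4ccccc43)nn2)[C@H](OC(C)=O)[C@@H](OC(C)=O)[C@@H]1OC(C)=O`: 53200 nM

In a functional assay on MCF7 cells (Homo sapiens) for cytotoxicity, read by sulforhodamine B assay, with a stated time of 48 h (a lower number here means a stronger inhibitor, a higher number a weaker inhibitor), compound 2 gives 34100 nM, the second highest of the three numbers; its nearest neighbour is compound 1 and its furthest is compound 3, with both gaps inside the scatter, so no order among the three can be claimed. The step of a 1.4-fold higher number from compound 1 to compound 2 (0.15 log units; within the scatter) is the one that bears on the new compound, since it concerns the same place. The step of a 1.6-fold higher number from compound 2 to compound 3 (0.19 log units; within the scatter) rests only on the fact that compounds 2 and 3 differ only in the configuration as drawn and says nothing about the group at that place.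

Compound 4 `CC(=O)OC[C@H]1O[C@@H](n2cc(CN3C(=O)/C(=C\c4cccs4)c4ccccc43)nn2)[C@H](OC(C)=O)[C@@H](OC(C)=O)[C@@H]1OC(C)=O` carries the change (thiophen-2-yl in place of 2-phenylethenyl on a double-bonded chain carbon bound to a double-bonded ring carbon). This undoes the extension seen in the step from compound 1 to compound 2 and puts a five-membered aromatic ring where compound 1 carries a six-membered one. As that measured step stayed inside the scatter, the expected step of a 1.4-fold lower number from compound 2 to compound 4 (0.13 log units; within the scatter) is likewise expected to stay within the scatter, with no direction claimed. For compound 4 the estimate in this assay is 25000 nM, with a range from 8000 nM to 80000 nM.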

Compound 4, half-maximal inhibitory concentration: 36100 nM
For compound 4 the middle estimate is 1.4-fold (0.16 log units) below the measured one; the range from low to high includes it.
By their numbers in this assay, from the lowest: compounds 1, 2, 4 and 3 (each within the scatter of the next, the first and the last beyond it).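

In this assay, thiophen-2-yl in place of 2-phenylethenyl gives a 1.1-fold higher number from compound 2 to compound 4 (0.02 log units; within the scatter), and thiophen-2-yl in place of phenyl gives a 1.5-fold higher number from compound 1 to compound 4 (0.17 log units; within the scatter). On a double-bonded chain carbon bound to a double-bonded ring carbon, a five-membered aromatic ring with a sulfur atom therefore cannot be told apart from either carbon-only group, so this position now tolerates a hetero atom in the ring without a readable shift in this series. No measured property of these groups bears on this result.

Open, as far as these compounds go, is whether a carboxylic acid or an amine at this place would give a step beyond the scatter. Also open, from the compounds shown here alone, is how the series reads with free hydroxyl groups on the sugar in place of the acetyl esters.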